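The source may hold more compounds than are shown below. What is called first, only, known or untested is meant among the compounds shown, and "the series" means these compounds.

Compound 1 `CC(C)c1cccc(C(C)C)c1NC(=O)NCC1(c2ccc(CC(C)(C)C)cc2)CCCC1`, compound 2 `CC(C)c1cccc(C(C)C)c1NC(=O)NCC1(c2cccc(OCc3ccccc3)c2)CCCC1` and compound 3 `CC(C)c1cccc(C(C)C)c1NC(=O)NCC1(c2cccc([N+](=O)[O-])c2)CCCC1` share one core and differ only in the aromatic group attached to a saturated ring carbon. In an assay on microsomes for inhibition of acyl-CoA:cholesterol acyltransferase (Oryctolagus cuniculus) (a lower number here means a stronger inhibitor, a higher number a weaker inhibitor), compound 1 gives 159 nM, compound 2 gives 30 nM and compound 3 gives 51 nM. Compound 3 thus holds the second highest number of the three: its value lies within the scatter of that of compound 2, whereas the step of a 3.1-fold lower number from compound 1 to compound 3 (0.49 log units; beyond the scatter) lies beyond it. The unmeasured partner is compound 4 `Cc1ccc(C2(CNC(=O)Nc3c(C(C)C)cccc3C(C)C)CCCC2)c(C)c1`, and the change is this: 2,4-dimethylphenyl in place of 3-nitrophenyl on a saturated ring carbon. Among the compounds with values here, two measured steps bear on it. The step of a 3.1-fold lower number from compound 1 to compound 3 (0.49 log units; beyond the scatter) shows that moving from 4-neopentylphenyl to 3-nitrophenyl at that place lowered the number, and the step of a 1.7-fold higher number from compound 2 to compound 3 (0.23 log units; within the scatter) shows that nitro and benzyloxy gave numbers within the scatter. Compound 4 returns to a ring without the nitro group, so a moderate rise is expected, a 2.0-fold higher number from compound 3 to compound 4 (0.29 log units; within the scatter). Compound 4 is therefore estimated at 100 nM, with a range from 40 nM to 250 nM.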

Compound 4, half-maximal inhibitory concentration: 50 nM
The estimate for compound 4 lay 2.0-fold (0.30 log units) above the measured number, and the stated range covers the measured number.
By their numbers in this assay, from the lowest: compounds 2, 4 and 3 (each within the scatter of the next); then compound 1.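

In this assay there is a 1.0-fold lower number from compound 3 to compound 4 (0.01 log units; within the scatter) when 2,4-dimethylphenyl replaces 3-nitrophenyl on a saturated ring carbon, so at this place a nitro group is not required for a number of this size. Set against 4-neopentylphenyl, 2,4-dimethylphenyl gives a 3.2-fold lower number from compound 1 to compound 4 (0.50 log units; beyond the scatter) and so keeps the gap seen with 3-nitrophenyl, which shows that this gap does not depend on the nitro group. No measurement shown here explains why these two different aromatic groups give matching numbers.

The compounds shown leave open whether one methyl group alone on the phenyl ring would give the same number, or whether both are needed. They also leave open how a phenyl ring carrying an amine or a carboxylic acid would behave at this place.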